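A few compounds are considered here, and "the series" means these few. Any claim that something is new, unique, unknown or untested is made for them only; others in the source may bear on it.

Compound 3 `C=CCn1cc(COc2cc(O)c3c(c2)O[C@H](c2ccc(OC)c(O)c2)CC3=O)nn1` gives 13800 nM in a functional assay on RAW264.7 cells (Mus musculus) for inhibition, read by Griess assay, with stated times of 2 h and 24 h (on this read-out higher numbers stand for weaker inhibition and lower numbers for stronger inhibition), the highest of the three numbers shown, though its gap to compound 1 `COc1ccc([C@@H]2CC(=O)c3c(O)cc(OCc4cn(C5CCCC5)nn4)cc3O2)cc1O`, which gives 10500 nM, and to compound 2 `CCCn1cc(COc2cc(O)c3c(c2)O[C@H](c2ccc(OC)c(O)c2)CC3=O)nn1`, which gives 9670 nM, lies within the scatter. Compound 4 `COc1ccc([C@@H]2CC(=O)c3c(O)cc(OCc4cn(Cc5ccccc5Cl)nn4)cc3O2)cc1O` differs from compound 3 by 2-chlorophenyl in place of vinyl on a saturated chain carbon bound to an aromatic nitrogen. The measured steps that bear on this position are a 1.1-fold lower number from compound 1 to compound 2 (0.04 log units; within the scatter), a 1.3-fold higher number from compound 1 to compound 3 (0.12 log units; within the scatter) and a 1.4-fold higher number from compound 2 to compound 3 (0.15 log units; within the scatter), each within the scatter; so far the group on the aromatic nitrogen has made no difference beyond the scatter, although none of those groups carried an aromatic ring. A step of a 1.2-fold lower number from compound 3 to compound 4 (0.06 log units; within the scatter) is therefore expected, none beyond the scatter. Compound 4 is estimated at 12000 nM, with a range from 5000 nM to 30000 nM.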

Compound 4, half-maximal inhibitory concentration: 6140 nM
Compound 4: the middle estimate sits 2.0-fold (0.29 log units) above what was measured; the range from low to high includes it.
By their numbers in this assay, from the lowest: compounds 4, 2, 1 and 3 (each within the scatter of the next, the first and the last beyond it).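

In this assay, going by these compounds alone, the step of a 2.2-fold lower number from compound 3 to compound 4 (0.35 log units; beyond the scatter) is the first at this position to go beyond the scatter, and it accompanies 2-chlorobenzyl, the first group here with an aromatic ring, in place of allyl. The other two steps, a 1.6-fold lower number from compound 2 to compound 4 (0.20 log units; within the scatter) and a 1.7-fold lower number from compound 1 to compound 4 (0.23 log units; within the scatter), stay within the scatter, so the group separates only from allyl. Nothing shown gives a reason for this step. Going by these compounds, whether the aromatic ring or the chlorine goes with the step stays open. A plain benzyl group on the same nitrogen would separate the two.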